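Swapping the acyl group on the shared core: working notes

A few compounds are considered here, and "the series" means these few. Any claim that something is new, unique, unknown or untested is made for them only; others in the source may bear on it.

Measured in a functional assay on HepG2 cells (Homo sapiens) for antiproliferative activity, read by MTT assay, with a stated time of 48 h (a lower number here means that less compound is needed, a higher number that more compound is needed for the effect), so far:
- compound 1 (`CC1=NN(C(=O)CCl)C(c2cc(Cl)ccc2O)C1`): 20300 nM
- compound 2 (`CC1=NN(C(=O)CBr)C(c2ccccc2O)C1`): 14400 nM

Compound 2 and compound 1 lie within the scatter of each other, so these two numbers set no order between them. Both compounds sit at the same general level, and compound 2 serves as the reference here (14400 nM). Compound 3 (`CC1=NN(C(=O)c2ccc(F)cc2)C(c2ccccc2O)C1`) carries 4-fluorophenyl in place of bromomethyl on a carbonyl carbon. Going by the values given here, no measured pair shows a change of this kind, so the expectation has no direct precedent and stays wide. In this assay the expected step (a 1.7-fold higher number from compound 2 to compound 3 (0.24 log units; within the scatter)) is no larger than the scatter, with a slight lean towards a higher number. The estimated value for compound 3 is 25000 nM (expected range 8000 nM to 80000 nM).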

Compound 3, half-maximal effective concentration: 39200 nM
For compound 3 the middle estimate is 1.6-fold (0.20 log units) below the measured one; measured number inside the range.
By their numbers in this assay, from the lowest: compounds 2, 1 and 3 (each within the scatter of the next, the first and the last beyond it).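

Going by these compounds alone, this is the first change made in one place only, and it shows that the carbonyl carbon position responds to the acyl group: in this assay the exchange gives a 2.7-fold higher number from compound 2 to compound 3 (0.43 log units; beyond the scatter) on the shared core. The step is modest, and compound 3 still gives a measurable 39200 nM with 4-fluorophenyl in place of bromomethyl, so an aromatic ring at this position does not abolish the read-out. No supporting evidence accounts for this step.

Within the data shown here, the single exchange removes bromomethyl and brings in 4-fluorophenyl together, so the contribution of each remains unseparated. On these data alone, how a plain methyl, an unsubstituted phenyl or an aminomethyl group on the same carbonyl carbon would read remains open.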